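Trifluoromethyl to methyl on the bicyclic amide of compound 2

This account rests on a few compounds, and the source may have more. Where it says the series, first, only, none or still open, it means among the compounds named here.

Three compounds have numbers in an assay on isolated protein for inhibition of tyrosine-protein kinase receptor UFO (Homo sapiens), read by LC-MS, with stated times of 30 min and 180 min; a lower number here means a stronger inhibitor, a higher number a weaker inhibitor. Compound 1 `CS(=O)(=O)c1cnc(Nc2ccc(O)cc2)nc1NCc1ccccc1` gives 1580 nM in this assay. Compound 2 `CNC(=O)c1sc(N2CC3CC2(CNC(=O)c2c[nH]c4ncc(C(F)(F)F)cc24)C3)nc1C(F)(F)F` gives 25.1 nM in this assay. Compound 3 `CNc1nc(OCC2CCC2)nc2c1ncn2Cc1c(F)cccc1F` gives 1580 nM in this assay. Compound 2 therefore stands lowest of the three, and its gaps to compound 1 and to compound 3 are both beyond the scatter; compound 1 and compound 3 are not distinguished from each other in this assay.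

Compound 4 `CNC(=O)c1sc(N2CC3CC2(CNC(=O)c2c[nH]c4ncc(C)cc24)C3)nc1C(F)(F)F` is not yet measured. It differs from compound 2 in one place only: methyl in place of trifluoromethyl on an aromatic carbon. Both groups carry no hydrogen-bond donor and no hydrogen-bond acceptor and no net charge, so the change is a matter of the group's size at that aromatic carbon. Among the measured compounds shown here, no pair of measured compounds shows this exchange, and no step is known for it, so the direction is uncertain; a step of modest size is expected rather than a large one, most likely toward a somewhat higher number, though a result within the scatter of compound 2 would not surprise. Compound 4 is expected to give about 60 nM in this assay, with a range from 20 nM to 200 nM. The expected step of a 2.4-fold higher number from compound 2 to compound 4 (0.38 log units; beyond the scatter) is estimated to be small, and it is anchored on the result of compound 2 at 25.1 nM.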

Compound 4, half-maximal inhibitory concentration in the tyrosine-protein kinase receptor UFO assay: 3.98 nM
Estimate against measurement, compound 4: 15-fold (1.18 log units) above; the measured number lies below the stated range.
By their numbers in the tyrosine-protein kinase receptor UFO assay, from the lowest: compound 4; then compound 2; then compounds 1 and 3 (each within the scatter of the next).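

In the tyrosine-protein kinase receptor UFO assay, trifluoromethyl on this aromatic carbon proves dispensable, and methyl serves better: a 6.3-fold lower number from compound 2 to compound 4 (0.80 log units; beyond the scatter). The step is beyond the scatter and gives the series its first measured reading at this position, one that compounds 1, 2 and 3 could not give, since none of them differs from another in one place only. In a physicochemical assay for solubility (on this read-out higher numbers stand for higher solubility and lower numbers for lower solubility), compound 2 gives < 1600 nM, which is a limit of the assay and not a number. In the physicochemical assay compound 4 gives < 1600 nM, which is also a limit of the assay and not a number. In the physicochemical assay the same exchange cannot be read: the limit of < 1600 nM in the physicochemical assay, at which 2 of the 2 values shown sit.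

Open, from the compounds shown here alone, is how hydrogen, chlorine, a methoxy group or an ethyl chain on this aromatic carbon would stand against methyl in the tyrosine-protein kinase receptor UFO assay, so a single step cannot separate a trend with group size from a result particular to methyl. Also open, going by these compounds, is whether methyl in place of the remaining trifluoromethyl of compound 4 would move the number in the same direction, and whether any exchange on this series gives a reading clear of the limit in the physicochemical assay.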